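Replacing the (4-nitrophenyl)carbamoyl group of compound 3

A few compounds are considered here, and "the series" means these few. Any claim that something is new, unique, unknown or untested is made for them only; others in the source may bear on it.

Of the compounds shown here, three have been measured in a functional assay on RS4-11 cells (Homo sapiens) for inhibition, read by CCK-8 assay, with a stated time of 48 h; a higher number here means a weaker inhibitor, a lower number a stronger inhibitor. Compound 1 `COc1ccc(Oc2ccccc2-c2ccsc2S(=O)(=O)N2CCN(C(=O)Nc3ccc([N+](=O)[O-])cc3)CC2)cc1OC` gives only a limit, > 50000 nM. Compound 3 `O=C(Nc1ccc([N+](=O)[O-])cc1)N1CCN(S(=O)(=O)c2sccc2-c2ccccc2Oc2ccc(O)c(O)c2)CC1` gives 14300 nM, the higher of the two actual numbers. Compound 2 `Cc1ccc(-c2ccsc2S(=O)(=O)NCCNC(=O)Nc2cc(Cl)cc(Cl)c2)c(Oc2ccc(O)c(O)c2)c1` stands lower, at 5100 nM, a gap beyond the usual scatter.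

Among the compounds with values here, the only measured step, an at least 3.4-fold lower number from compound 1 to compound 3 (0.54 log units; beyond the scatter), comes from 3,4-dihydroxyphenyl in place of 3,4-dimethoxyphenyl. Compound 4 `O=S(=O)(c1sccc1-c1ccccc1Oc1ccc(O)c(O)c1)N1CCN(C(=S)Nc2ccc(Cl)cc2)CC1` keeps that 3,4-dihydroxyphenyl group and changes elsewhere: a group of 10 heavy atoms (7 carbon, 1 nitrogen, 1 sulfur, 1 chlorine; one six-membered aromatic ring of carbon only) in place of a group of 12 heavy atoms (7 carbon, 2 nitrogen, 3 oxygen; one six-membered aromatic ring of carbon only), on an amine nitrogen in a ring, with (4-nitrophenyl)carbamoyl leaving. Within the data shown here, no measured step touches this group, so the step from the dimethoxy to the dihydroxy compound gives no direct size for the change, and the expectation remains loose.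

Among the measured compounds shown here, the only hint comes from compound 2, which also bears chlorine on an aromatic ring of carbon only and gives 5100 nM, although it differs from compound 3 in more than one place. On that weak basis, a small shift toward a lower number is expected in this assay, with the estimated step being a 1.8-fold lower number from compound 3 to compound 4 (0.25 log units; within the scatter), which would not clearly leave the scatter. For compound 4 the estimated value is 8000 nM, with an expected range from 2500 nM to 25000 nM.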

Compound 4, half-maximal inhibitory concentration: 7500 nM
Compound 4: the middle estimate sits 1.1-fold (0.03 log units) above what was measured; the measured number falls inside the stated range.
By their numbers in this assay, from the lowest: compounds 2, 4 and 3 (each within the scatter of the next, the first and the last beyond it). At a limit, above all of these: compound 1.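

In this assay, within the data shown here, the step of a 1.9-fold lower number from compound 3 to compound 4 (0.28 log units; within the scatter) is the first measured one that touches the amine nitrogen in the ring, and it leaves the two compounds indistinguishable. With the 3,4-dihydroxyphenyl group and the rest of the core held constant, the (4-nitrophenyl)carbamoyl group can therefore give way to a group with sulfur and chlorine, and with fewer heavy atoms and hydrogen-bond acceptors, without a change that clears the scatter. Both ends of this step are actual numbers, and the step has a definite size. The earlier step at the dihydroxyphenyl group gave only a bound, since compound 1 stands at a limit of the assay: the limit of > 50000 nM in this assay, at which 1 of the 4 values shown sits.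

The step replaces several features at once, so the contributions of the sulfur and the chlorine cannot be separated, and it cannot be said whether either would matter alone. On these data alone, it also remains open how this position would respond to a much smaller group, such as an acetyl, or to a group carrying an amine or a carboxylic acid on the aromatic ring.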